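Furan for Thiophene on a Shared Nucleoside Core

The compounds below may be only part of what the source reports. "The series", "measured", "known", "first", "only" and "open" are said of these compounds alone.

Four compounds share one core. Compound 1 `O=c1[nH]cnc2c1c(-c1ccoc1)cn2[C@@H]1O[C@H](CO)[C@@H](O)[C@H]1O` and compound 2 `O=c1[nH]cnc2c1c(-c1cccs1)cn2[C@@H]1O[C@H](CO)[C@@H](O)[C@H]1O` differ in one place only: furan-3-yl in place of thiophen-2-yl on an aromatic carbon. Compound 3 `Nc1nc2c(c(-c3cccs3)cn2[C@@H]2O[C@H](CO)[C@@H](O)[C@H]2O)c(=O)[nH]1` carries the core of compound 2 with one added group, (amino in place of hydrogen on an aromatic carbon). Compound 4 `Nc1nc2c(c(-c3ccoc3)cn2[C@@H]2O[C@H](CO)[C@@H](O)[C@H]2O)c(=O)[nH]1` has not yet been tested.

The three tested compounds were run in a functional assay on CEM-DNR-bulk cells (Homo sapiens), read by MTT assay, with a stated time of 72 h; a lower number here means a stronger inhibitor, a higher number a weaker inhibitor. Compound 1 reaches only the limit of the assay, > 20000 nM, which is not a number. Compound 2 likewise gives only the limit, > 20000 nM. Compound 3 also stops at the limit, > 20000 nM. The step from compound 2 to compound 1 is therefore a step that the two limits leave unreadable from compound 2 to compound 1, and that from compound 2 to compound 3 is a step that the two limits leave unreadable from compound 2 to compound 3. That every value sits at the limit of > 20000 nM in this assay, at which 3 of the 3 values shown sit, means no difference among the three can be read.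

The change from compound 3 to compound 4 is furan-3-yl in place of thiophen-2-yl on an aromatic carbon. Its place is word for word the same as that of the change from compound 2 to compound 1, so it is the same change, made on the core that differs by the amino group. Among the compounds with values here, because compound 2 and compound 1 both sat at the limit of > 20000 nM in this assay, at which 3 of the 3 values shown sit, that earlier step has no readable size, and the only guide is that every tested compound stayed at the limit.

Compound 4 is expected to stay at the limit as well, with an estimated middle of 30000 nM and an expected range from 12000 nM to 100000 nM. The step from compound 3 to compound 4 is expected to be a step that the limit leaves unreadable from compound 3 to compound 4.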

Compound 4, half-maximal inhibitory concentration: 15000 nM
Beside the measured number, compound 4's estimate is 2.0-fold (0.30 log units) above it; the range from low to high includes it.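

In this assay, furan-3-yl in place of thiophen-2-yl on the core that carries the amino group gives an at least 1.3-fold lower number from compound 3 to compound 4 (0.12 log units; that floor lies within the scatter), and the amino group added to the core of compound 1 gives an at least 1.3-fold lower number from compound 1 to compound 4 (0.12 log units; that floor lies within the scatter). Within the data shown here, both figures are floors that lie within the scatter, so neither shows that the change really lowers the number, although compound 4 is the only one of the four compounds with a measured number rather than a limit. The remaining steps cannot be read, including the same ring change on the core without the amino group, so nothing shows whether this change has the same size on both cores, or any readable size on the core without the amino group: the limit of > 20000 nM in this assay, at which 3 of the 4 values shown sit.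

The compounds shown leave open how far compounds 1, 2 and 3 lie past the limit, and so whether either change has a real size in this series. They also leave open what other rings, such as phenyl or furan-2-yl, would give at the same place, and whether a methylamino group or a carboxylic acid in place of the amino group would move the number further.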